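Cyclopropyl for chloro on the benzylamine core

This account rests on a few compounds, and the source may have more. Where it says the series, first, only, none or still open, it means among the compounds named here.

Compound 2 `C[C@H](NCc1ccc(OCc2cccc(F)c2)cc1Cl)C(N)=O` gives 12000 nM in an assay on Sf9 cells for inhibition of Amine oxidase [flavin-containing] A (Homo sapiens), with stated times of 15 min and 60 min (on this read-out higher numbers stand for weaker inhibition and lower numbers for stronger inhibition), the highest number among the three measured compounds. Compound 1 `NC(=O)[C@@H]1CCN1Cc1ccc(OCc2cccc(F)c2)cc1Cl` gives 2130 nM and compound 3 `C#CCN(Cc1ccc(OCc2cccc(F)c2)cc1Cl)[C@@H](C)C(N)=O` gives 5600 nM. The steps seen so far are a 5.6-fold higher number from compound 1 to compound 2 (0.75 log units; beyond the scatter) and a 2.1-fold lower number from compound 2 to compound 3 (0.33 log units; beyond the scatter), both changes at the amine side of the shared core. Compound 4 `C[C@H](NCc1ccc(OCc2cccc(F)c2)cc1C1CC1)C(N)=O` differs from compound 2 by cyclopropyl in place of chloro on an aromatic carbon. Going by the values given here, neither measured step touches the aromatic ring, so no step within the set bears on this change directly, and its size and direction in this assay cannot be drawn from the numbers. Compound 4 is therefore expected at 10000 nM, with a wide range from 3000 nM to 40000 nM. The step expected is a 1.2-fold lower number from compound 2 to compound 4 (0.08 log units; within the scatter), not beyond the usual scatter.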

Compound 4, half-maximal inhibitory concentration: 75200 nM
Compound 4: the middle estimate sits 7.5-fold (0.88 log units) below what was measured; measured number above the stated range.
By their numbers in this assay, from the lowest: compound 1; then compound 3; then compound 2; then compound 4.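

In this assay, the aromatic carbon ortho to the ((1-carbamoylethyl)amino)methyl group proves to matter: cyclopropyl in place of chloro gives a 6.3-fold higher number from compound 2 to compound 4 (0.80 log units; beyond the scatter). Going by these compounds alone, this is the first change on the ring itself, and it shows that chloro is not freely exchangeable for cyclopropyl on this amine side. No data at hand explain the step. Within the data shown here, only this one pair bears on this carbon, so how methyl, bromo or methoxy would read there stays open. Also open, as far as these compounds go, is whether cyclopropyl gives a similar step on the amine sides of compound 1 and compound 3.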